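Swapping the Fluoropyridine for a Fluorinated Methylsulfinylphenyl

The source may hold more compounds than are shown below. What is called first, only, known or untested is meant among the compounds shown, and "the series" means these compounds.

Compound 1 `CC(C)OC(=O)N1CCC(Oc2ncnc3c2CCN3c2ccc(S(C)(=O)=O)nc2)CC1` and compound 2 `CC(C)OC(=O)N1CCC(Oc2ncnc3c2CCN3c2ccc(F)cn2)CC1` share a core and differ only in the aromatic group carried on the ring nitrogen. In a functional assay on CHO-K1 cells for agonist activity at Glucose-dependent insulinotropic receptor (Homo sapiens), read by a luciferase reporter, with a stated time of 5 h (a lower number here means that less compound is needed, a higher number that more compound is needed for the effect), compound 1 gives 251 nM. Compound 2 reaches only the limit of the assay, > 10000 nM, so no number is known for it. For the measured compounds named here, the single measured step, an at least 39-fold higher number from compound 1 to compound 2 (1.60 log units; beyond the scatter), is large, and it rests on (the limit of > 10000 nM in this assay, at which 1 of the 2 values shown sits), so its true size is unknown. Compound 3 `CC(C)OC(=O)N1CCC(Oc2ncnc3c2CCN3c2ccc([S@@+](C)[O-])c(F)c2)CC1` has not yet been measured. The change from compound 2 to compound 3 is a group of 10 heavy atoms (7 carbon, 1 oxygen, 1 fluorine, 1 sulfur; one six-membered aromatic ring of carbon only) in place of a group of 7 heavy atoms (5 carbon, 1 nitrogen, 1 fluorine; one six-membered aromatic ring with 1 hetero atom), on a nitrogen on an aromatic ring in a ring. In part this reverses the measured step: the methylsulfinyl group on a carbon-only ring stands nearer to the methylsulfonyl pyridine of compound 1 than to the fluoropyridine of compound 2, though the ring and the sulfur group still differ from compound 1. Since the measured step was an at least 39-fold higher number from compound 1 to compound 2 (1.60 log units; beyond the scatter), a step in the opposite direction, well beyond the scatter, is expected here, an at least 20-fold lower number from compound 2 to compound 3 (1.30 log units; beyond the scatter). Compound 3 is therefore estimated at 500 nM in this assay, with a likely range from 120 nM to 3500 nM.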

Compound 3, half-maximal effective concentration: 631 nM
Compound 3: the middle estimate sits 1.3-fold (0.10 log units) below what was measured, and the stated range covers the measured number.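

In this assay, the step of an at least 15-fold lower number from compound 2 to compound 3 (1.19 log units; beyond the scatter) shows that a carbon-only aromatic ring on this nitrogen can carry measurable activity, so among these compounds a pyridine ring is not required at this place. The step of a 2.5-fold higher number from compound 1 to compound 3 (0.40 log units; beyond the scatter) is modest but beyond the scatter: compound 3 remains short of compound 1, yet the ring, the sulfur group and the fluorine all differ between them, so the gap cannot be assigned to any one of these changes. The true size of the step to compound 3 remains unknown, as compound 2 gives a limit of the assay and not a number: the limit of > 10000 nM in this assay, at which 1 of the 3 values shown sits.

The compounds shown do not separate the contributions of the ring nitrogen, the fluorine and the change from methylsulfonyl to methylsulfinyl, and they do not show whether the defined stereocentre at sulfur matters to the result. From the compounds shown here alone, it also remains open whether methylsulfonyl on the carbon-only ring, or a nitrile or a carboxylic acid in place of the sulfur group, would keep or improve the number seen for compound 3.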